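The source may report more compounds than this note shows. Statements on the series, on what has been measured and on what is new or still open speak of the compounds shown alone.

Measured in a functional assay on MCF7 cells (Homo sapiens) for antiproliferative activity, read by MTT assay, with a stated time of 24 h; a higher number here means a weaker inhibitor, a lower number a stronger inhibitor:
- Compound 1 `CCn1c(C(=O)N[C@H](C)C(=O)OC)ccc1C(CC)(CC)c1ccc(OCS(=O)(=O)c2ccccc2)c(C)c1`: > 50000 nM, a limit of the assay
- Compound 2 `CCN(CC)CCNC(=O)c1ccc(C(CC)(CC)c2ccc(OCS(=O)(=O)c3ccccc3)c(C)c2)n1CC`: 4680 nM
- Compound 3 `CCN(CC)CCNC(=O)c1ccc(C(CC)(CC)c2ccc(OCSC)c(C)c2)n1CC`: 5160 nM

Compound 3 stands within the scatter of compound 2, so no order can be drawn between the two. Compound 4 `CCN(CC)CCNC(=O)c1ccc(C(CC)(CC)c2ccc(OCSc3ccccc3)c(C)c2)n1CC` carries phenyl in place of methyl on a sulfur. The closest measured change is a 1.1-fold higher number from compound 2 to compound 3 (0.04 log units; within the scatter), with methylsulfanyl in place of phenylsulfonyl on a saturated chain carbon bound to an oxygen on an aromatic ring. The large step of an at least 10-fold lower number from compound 1 to compound 2 (1.02 log units; beyond the scatter) lies on an amide-type nitrogen, so it bears little on this change. No shift beyond the scatter is therefore expected. The estimated change is a 1.1-fold lower number from compound 3 to compound 4 (0.03 log units; within the scatter). Compound 4 is expected at 4800 nM, with an estimated range of 2200 nM to 10500 nM.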

Compound 4, half-maximal inhibitory concentration in the MCF7 assay: 4900 nM
The estimate for compound 4 lay 1.0-fold (0.01 log units) below the measured number; measured number inside the range.
By their numbers in the MCF7 assay, from the lowest: compounds 2, 4 and 3 (each within the scatter of the next). At a limit, above all of these: compound 1.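

In the MCF7 assay, neither change at the sulfur gives a shift that can be read: a 1.1-fold lower number from compound 3 to compound 4 (0.02 log units; within the scatter) for phenyl in place of methyl, and a 1.0-fold higher number from compound 2 to compound 4 (0.02 log units; within the scatter) for phenylsulfanyl in place of phenylsulfonyl. The same phenyl for methyl change does register in a physicochemical assay for solubility, read by HPLC, at pH 7.4 (a lower number here means a less soluble compound, a higher number a more soluble compound), where compound 3 gives 74.6 ug/mL and compound 4 gives 25.6 ug/mL: the measured solubility of compound 3, 74.6 ug/mL, and of compound 4, 25.6 ug/mL, a 2.9-fold lower number (0.46 log units; beyond the scatter). On these data alone, whether an amine or a carboxylic acid in place of phenyl on the sulfur would shift either read-out remains open, as does the result of methylsulfonyl on the saturated chain carbon.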